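The source may report more compounds than this note shows. Statements on the series, on what has been measured and on what is new or still open speak of the compounds shown alone.

Compound 1 `COc1cc(CSc2cc(Cl)c(-c3nnc(-c4ccc(Cl)cc4)s3)cc2S(=O)(=O)NC(=N)NO)cc(OC)c1OC` gives 16200 nM in a functional assay on UACC-62 cells (Homo sapiens); a higher number here means a weaker inhibitor of growth, a lower number a stronger inhibitor of growth. Compound 2 `N=C(NO)NS(=O)(=O)c1cc(-c2nnc(-c3ccc(Cl)cc3)s2)c(Cl)cc1SCc1ccccc1` gives 2020 nM in this assay.

Within the data shown here, compound 1 stands at the highest of the two numbers; the only measured step is an 8.0-fold lower number from compound 1 to compound 2 (0.90 log units; beyond the scatter). Compound 3 `COc1cc(CSc2cc(Cl)c(-c3nc(-c4ccccc4)no3)cc2S(=O)(=O)NC(=N)NO)cc(OC)c1OC` differs from compound 1 by 3-phenyl-1,2,4-oxadiazol-5-yl in place of 5-(4-chlorophenyl)-1,3,4-thiadiazol-2-yl on an aromatic carbon. Among the measured compounds shown here, that measured step changes a different part of the shared core, so no measured step bears directly on this change. Compound 3 is therefore expected to stay close to compound 1, with a 1.2-fold lower number from compound 1 to compound 3 (0.06 log units; within the scatter) estimated not to go beyond the scatter. The estimate for compound 3 is 14000 nM, between 3500 nM and 50000 nM.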

Compound 3, concentration for 50% growth inhibition: 3090 nM
Beside the measured number, compound 3's estimate is 4.5-fold (0.66 log units) above it, and the stated range ends above it.
By their numbers in this assay, from the lowest: compounds 2 and 3 (each within the scatter of the next); then compound 1.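

The aromatic carbon para to a large group proves to matter as well: 3-phenyl-1,2,4-oxadiazol-5-yl in place of 5-(4-chlorophenyl)-1,3,4-thiadiazol-2-yl gives a 5.2-fold lower number from compound 1 to compound 3 (0.72 log units; beyond the scatter) in this assay. Until now, only the group on the sulfur had been seen to move this number. No measurement bears on the reason for this step.

The change replaces the ring and removes the chloro group together, so their shares stay unseparated. Also open, going by these compounds, are how 3-(4-chlorophenyl)-1,2,4-oxadiazol-5-yl or a simple amine at this carbon would read, and whether the step holds with a benzyl group on the sulfur.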